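Swapping chloro for bromo on a hydroxyphenyl hydrazone

A few compounds are considered here, and "the series" means these few. Any claim that something is new, unique, unknown or untested is made for them only; others in the source may bear on it.

Compound 1 `O=C(N/N=C/c1ccco1)c1cccc(S(=O)(=O)N2CCOCC2)c1` carries a furan-2-yl group on the carbon that is double-bonded to nitrogen. In a functional assay on PC-3 cells (Homo sapiens) for antiproliferative activity, read by MTT assay, with a stated time of 72 h (a higher number here means a weaker inhibitor, a lower number a stronger inhibitor), compound 1 gives > 100000 nM, which is a limit of the assay rather than a number. Compound 2 `CCOc1cccc(/C=N/NC(=O)c2cccc(S(=O)(=O)N3CCOCC3)c2)c1O` gives 15300 nM, and compound 3 `O=C(N/N=C/c1cc(Cl)ccc1O)c1cccc(S(=O)(=O)N2CCOCC2)c1` gives 10500 nM. Replacing the furan-2-yl group by a substituted hydroxyphenyl group gave an at least 6.5-fold lower number from compound 1 to compound 2 (0.81 log units; beyond the scatter) and an at least 9.5-fold lower number from compound 1 to compound 3 (0.97 log units; beyond the scatter). Between the two hydroxyphenyl compounds the gap is small: a 1.5-fold lower number from compound 2 to compound 3 (0.16 log units; within the scatter). Compound 3 therefore stands alongside compound 2, with no separation between them beyond the scatter.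

Compound 4 `O=C(N/N=C/c1cc(Br)ccc1O)c1cccc(S(=O)(=O)N2CCOCC2)c1` has not yet been measured. It differs from compound 3 by bromo in place of chloro on an aromatic carbon. Going by the values given here, none of the measured steps exchanges one halogen for another, so this change has no direct precedent among the measured compounds. Among the compounds with values here, the steps that do touch this part of the molecule exchange the whole aryl group, which is a far larger alteration than the one from compound 3 to compound 4. Compound 4 is therefore expected to show a 1.2-fold lower number from compound 3 to compound 4 (0.07 log units; within the scatter), a step not beyond the scatter. For compound 4 the expected value in this assay is 9000 nM, with a range from 3500 nM to 25000 nM.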

Compound 4, half-maximal inhibitory concentration: 7230 nM
Beside the measured number, compound 4's estimate is 1.2-fold (0.10 log units) above it; the range from low to high includes it.
By their numbers in this assay, from the lowest: compounds 4, 3 and 2 (each within the scatter of the next, the first and the last beyond it). At a limit, above all of these: compound 1.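

Going by these compounds alone, the first exchange of one halogen for another at this position, on an aromatic carbon para to a hydroxy group, gives a 1.5-fold lower number from compound 3 to compound 4 (0.16 log units; within the scatter), so in this assay the chloro and bromo compounds cannot be told apart. The step of a 2.1-fold lower number from compound 2 to compound 4 (0.33 log units; beyond the scatter) is modest, but it gives the first separation beyond the scatter among the hydroxyphenyl compounds, since the corresponding step from compound 2 to compound 3 stayed within it; as compound 3 and compound 4 lie within the scatter of each other, this does not set one halogen above the other. The step of an at least 13-fold lower number from compound 1 to compound 4 (1.14 log units; beyond the scatter) is the largest shown for an exchange of the whole aryl group, but it counts from a value of compound 1 that is a limit of the assay and not a number: the limit of > 100000 nM in this assay, at which 1 of the 4 values shown sits.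

The compounds shown leave open what an iodo group, a methoxy group or an amine would do on this same aromatic carbon. They also leave open whether the hydroxy group matters, as every compound with a phenyl group here carries one and a halogen-bearing phenyl without it is not among them.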